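Thione to ethoxy on the triazole ring of compound 1

This account rests on a few compounds, and the source may have more. Where it says the series, first, only, none or still open, it means among the compounds named here.

Measured compounds:
compound 1 `S=c1[nH]nc(Cc2ccc(Cl)cc2Oc2ccccc2Cl)[nH]1`, 124%
compound 2 `CCSc1nnc(Cc2ccccc2Oc2ccccc2)[nH]1`, 132%
compound 3 `CCCSc1nnc(Cc2ccccc2Oc2ccccc2)[nH]1`, 128%

In a functional assay on the whole organism (strain NMRI) with Mus musculus as the target, with a stated time of 60 min, at a dose of 5 mg/kg by the intraperitoneal route (on this read-out lower numbers stand for a weaker effect and higher numbers for a stronger effect at the one dose given), compound 1 gives 124%. Its number lies within the usual scatter of compound 3, which gives 128%, and of compound 2, which gives 132%, so the three measured compounds cannot be told apart on this read-out.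

Compound 4 `CCOc1nnc(Cc2ccc(Cl)cc2Oc2ccccc2Cl)[nH]1` is not yet measured. It differs from compound 1 in one place: a group of 8 heavy atoms (4 carbon, 3 nitrogen, 1 oxygen; one five-membered aromatic ring with 3 hetero atoms) in place of a group of 6 heavy atoms (2 carbon, 3 nitrogen, 1 sulfur; one five-membered aromatic ring with 3 hetero atoms), on a saturated chain carbon bound to an aromatic carbon.

Within the data shown here, only one measured step exists, a number 4 percentage points lower from compound 2 to compound 3 (within the scatter), a change at the chain on the sulfur of the shared core rather than at the ring itself. It bears on the present step only loosely, by showing that a small change at that end of the molecule left the read-out unchanged within the scatter. Among the measured compounds shown here, no measured pair shows the exchange of sulfur for oxygen on the five-membered ring, so the expectation rests on the narrow spread of all three values.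

Compound 4 is therefore expected to give about 125%, between 105% and 145%, a step of a number 1 percentage points higher from compound 1 to compound 4 (within the scatter) that is estimated to stay within the scatter.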

Compound 4, a percentage reported as activity, at one dose (the size of the read-out at that dose, not a potency): 120%
Estimate against measurement, compound 4: 5 percentage points above, within the range that was stated.
By their numbers in this assay, from the lowest: compounds 4, 1, 3 and 2 (each within the scatter of the next, the first and the last beyond it).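

Replacing the group of 6 heavy atoms with the group of 8 heavy atoms on the saturated chain carbon bound to an aromatic carbon gives a number 4 percentage points lower from compound 1 to compound 4 (within the scatter) in this assay, so compound 1 and compound 4 cannot be told apart on this read-out. The earlier step, a number 4 percentage points lower from compound 2 to compound 3 (within the scatter), touched only the chain on the sulfur, whereas this one shows that the sulfur itself can be exchanged for an oxygen carrying a chain, and the double bond outside aromatic rings lost, with the number staying within the scatter, even though the count of hydrogen-bond donors falls from 2 to 1 and that of acceptors rises from 2 to 3. Nothing available explains why the read-out tolerates this exchange.

The compounds shown leave open whether an amine, a carboxylic acid or a longer chain on the oxygen at this end of the molecule would also stay within the scatter. They also leave open what the chlorine atoms contribute, and whether this tolerance would hold at doses other than the single one given.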